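The source may hold more compounds than are shown below. What is called first, only, known or untested is meant among the compounds shown, and "the series" means these compounds.

Measured compounds in a functional assay on CCRF-CEM cells (Homo sapiens) for cytotoxicity, read by MTT assay, with a stated time of 72 h; on this read-out lower numbers stand for higher toxicity in this test and higher numbers for lower toxicity in this test:

Compound 1, `CSc1ccc(CNc2nc(SC)nc3ncccc23)cc1`: 59000 nM.
Compound 2, `CSc1nc(NCCCCCO)c2ccccc2n1`: > 100000 nM, which is a limit of this assay and not a number.
Compound 3, `[SeH]c1nc(NCc2ccccc2)c2ccccc2n1`: > 100000 nM, again a limit of this assay rather than a number.

Among the three values, compound 1 carries the only actual number; the other two sit at the limit of > 100000 nM in this assay, at which 2 of the 3 values shown sit. Going by the values given here, no step between two measured compounds that differ in one place can be drawn from these three, so the series gives no measured step to lean on.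

The step of interest goes from compound 1 to compound 4, `CSc1nc(NCc2ccccc2)c2cccnc2n1`, not yet measured in this assay. The change is hydrogen in place of methylsulfanyl on an aromatic carbon: methylsulfanyl leaves and hydrogen enters on an aromatic carbon of a six-membered aromatic ring of carbon only. The core of compound 1 is kept.

Among the compounds with values here, with no measured step in this assay to compare against, the expectation is a small step, at most of the order of the usual scatter, and if anything toward lower toxicity in this assay, since the only number in hand, compound 1 at 59000 nM, is itself already weak. Compound 4 is estimated at 80000 nM, expected between 25000 nM and 250000 nM. The expected step is a 1.4-fold higher number from compound 1 to compound 4 (0.13 log units; within the scatter).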

Compound 4, concentration lethal to 50% of the cells: > 100000 nM
Compound 4: only a limit was reported (the forecaster's own chance of this, stated with the estimate: 35%); middle value at least 1.2-fold (0.09 log units) from the limit.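

In this assay compound 4 gives > 100000 nM, which is a limit of the assay and not a number. Taking methylsulfanyl off the aromatic carbon para to a large group gives the first step in the series, an at least 1.6-fold higher number from compound 1 to compound 4 (0.22 log units; that floor lies within the scatter), so the change can be read only as a floor, and that floor alone does not separate the pair. What the pair adds is that compound 1, with methylsulfanyl at this place, remains the only one of the four compounds with an actual number, while with hydrogen at this place the read-out gives no number either: the limit of > 100000 nM in this assay, at which 3 of the 4 values shown sit.

From the compounds shown here alone, whether the true step goes beyond the scatter stays open, and only a number for compound 4 could settle it. Also open, going by these compounds, is how other groups at this place, such as methoxy, an amine or a carboxylic acid, would read in this assay, and whether any of them would bring a value clear of the limit.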